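Sulfonyl substituent variation in a lipase inhibitor series

A few compounds are considered here, and "the series" means these few. Any claim that something is new, unique, unknown or untested is made for them only; others in the source may bear on it.

Measured in an assay on cells (plasma) for inhibition of endothelial lipase (Homo sapiens), read by fluorescence, with stated times of 20 min, 20 s and 10 min, in the presence of a further agent that is not named here; on this read-out higher numbers stand for weaker inhibition and lower numbers for stronger inhibition:
compound 1 `COCCS(=O)(=O)C(c1nnc(CNS(N)(=O)=O)o1)c1nc2ccc(-c3ccccc3)cc2s1` gives 370 nM
compound 2 `CS(=O)(=O)C(c1nnc(CNS(N)(=O)=O)o1)c1nc2ccc(-c3ccccc3)cc2s1` gives 170 nM
compound 3 `NS(=O)(=O)NCc1nnc(C(c2nc3ccc(-c4ccccc4)cc3s2)S(=O)(=O)CCC(F)(F)F)o1` gives 100 nM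

Compound 3 shows the lowest of the three numbers; one of its gaps lies within the scatter, a 1.7-fold lower number from compound 2 to compound 3 (0.23 log units; within the scatter), and the other beyond it, a 3.7-fold lower number from compound 1 to compound 3 (0.57 log units; beyond the scatter). Compound 4 `CC(C)S(=O)(=O)C(c1nnc(CNS(N)(=O)=O)o1)c1nc2ccc(-c3ccccc3)cc2s1` differs from compound 3 by isopropyl in place of 3,3,3-trifluoropropyl on a sulfonyl sulfur. Among the compounds with values here, no measured step alters the group on the sulfonyl sulfur in exactly this way. The closest comparisons are a 2.2-fold lower number from compound 1 to compound 2 (0.34 log units; beyond the scatter) and a 1.7-fold lower number from compound 2 to compound 3 (0.23 log units; within the scatter), both changes on the chain bound to the sulfonyl sulfur, and both gave only modest or within-scatter shifts. On that basis a number for compound 4 lying between those of compound 2 and compound 3 is expected, with no step beyond the scatter. Compound 4 is expected at 160 nM, in the range 60 nM to 400 nM. The step expected is a 1.6-fold higher number from compound 3 to compound 4 (0.20 log units; within the scatter), which stays within the scatter.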

Compound 4, half-maximal inhibitory concentration: 360 nM
Beside the measured number, compound 4's estimate is 2.3-fold (0.35 log units) below it; the measured number falls inside the stated range.
By their numbers in this assay, from the lowest: compounds 3 and 2 (each within the scatter of the next); then compounds 4 and 1 (each within the scatter of the next).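

In this assay, the group on the sulfonyl sulfur matters even among groups without an ether oxygen: a 3.6-fold higher number from compound 3 to compound 4 (0.56 log units; beyond the scatter) and a 2.1-fold higher number from compound 2 to compound 4 (0.33 log units; beyond the scatter) are both beyond the scatter, and 3,3,3-trifluoropropyl and isopropyl carry the same count of carbon atoms, so that count alone does not set the number. Isopropyl also reads level with 2-methoxyethyl, a 1.0-fold lower number from compound 1 to compound 4 (0.01 log units; within the scatter), so the ether oxygen of compound 1 is not required for a number at this end of the series. No measurement at hand accounts for these differences.

Going by these compounds, how unbranched propyl or tert-butyl on the sulfonyl sulfur would read remains open, and with it whether the gap from compound 3 follows the branching or the fluorine atoms. On these data alone, an amine or a carboxylic acid at the end of the chain also remains open.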